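Cyclising the amine on the dioxolane series

A few compounds are considered here, and "the series" means these few. Any claim that something is new, unique, unknown or untested is made for them only; others in the source may bear on it.

Compound 2 `CCC[C@H](N)[C@H]1COC(c2ccccc2)(c2ccccc2)O1` gives 3450 nM in a functional assay (brain) for displacement of a labelled ligand, with Rattus norvegicus as the target (a higher number here means a weaker inhibitor, a lower number a stronger inhibitor), the highest of the two numbers in hand. Compound 1 `CC[C@]1(c2ccccc2O)OC[C@H]([C@@H]2CCCCN2)O1` gives 293 nM in this assay, a considerably lower number, and it carries a cyclic amine while compound 2 carries an open chain. Compound 3 `c1ccc(C2(c3ccccc3)OC[C@H]([C@@H]3CCCN3)O2)cc1` differs from compound 2 in one place: pyrrolidin-2-yl in place of 1-aminobutyl on a saturated ring carbon. Within the data shown here, no step between two measured compounds isolates this change, so the expectation rests only on the direction suggested by compound 1 giving 293 nM. The expected step in this assay a 3.8-fold lower number from compound 2 to compound 3 (0.58 log units; beyond the scatter) is a moderate fall in the number. Compound 3 is estimated at 900 nM, ranging from 250 nM to 3200 nM.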

Compound 3, inhibition constant: > 10000 nM
Compound 3 was reported as a limit; the forecaster's own chance of this, stated with the estimate: 3%; middle value at least 11-fold (1.04 log units) away from the limit.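

On the core of compound 2, pyrrolidin-2-yl in place of 1-aminobutyl gives an at least 2.8-fold higher number from compound 2 to compound 3 (0.46 log units; beyond the scatter) in this assay. At this saturated ring carbon, closing the chain into a ring therefore does not lower the number, so a cyclic amine alone cannot account for the value of compound 1, which differs from compound 2 in more than one place. Compound 3 is reported only as a limit: the limit of > 10000 nM in this assay, at which 1 of the 3 values shown sits.

From the compounds shown here alone, the full size of the step remains unknown. Also open, going by these compounds, is how azetidin-2-yl, or a methyl on the nitrogen of pyrrolidin-2-yl, would read at this carbon on the same core.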